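A few compounds are considered here, and "the series" means these few. Any claim that something is new, unique, unknown or untested is made for them only; others in the source may bear on it.

Measured compounds:
- compound 1, `CC(C(=O)NCc1ccc(C(C)(C)C)nc1N1CCCC1)c1ccc(NS(C)(=O)=O)c(F)c1`: 1.2 nM
- compound 2, `CC(C)CCOc1nc(C(C)(C)C)ccc1CNC(=O)C(C)c1ccc(NS(C)(=O)=O)c(F)c1`: 0.8 nM

In an assay on cells for antagonist activity at transient receptor potential cation channel subfamily V member 1 (Homo sapiens), read by FLIPR and calcium flux, with a stated time of 6 min (a higher number here means a weaker inhibitor, a lower number a stronger inhibitor), compound 2 gives 0.8 nM, the lower of the two numbers, although the step of a 1.5-fold lower number from compound 1 to compound 2 (0.18 log units; within the scatter) lies within the scatter, so the two compounds cannot be separated on these values. Compound 3, `CC(C(=O)NCc1ccc(C(C)(C)C)nc1OC1CCCC1)c1ccc(NS(C)(=O)=O)c(F)c1`, has not yet been measured; it differs from compound 2 by the change (cyclopentyl in place of isopentyl on an oxygen on an aromatic ring). Going by the values given here, no measured step concerns this exact change. Among the compounds with values here, the only measured step, from compound 1 to compound 2, replaced pyrrolidin-1-yl on an aromatic carbon with isopentyloxy and came out within the scatter, so the one variation seen at this site left the number essentially unchanged. On that basis the step of a 1.3-fold higher number from compound 2 to compound 3 (0.10 log units; within the scatter) from compound 2 to compound 3 is expected to be none beyond the scatter in this assay. Compound 3 is therefore estimated at 1 nM in this assay, with a range of 0.4 nM to 2.5 nM.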

Compound 3, inhibition constant: 1.5 nM
For compound 3 the middle estimate is 1.5-fold (0.18 log units) below the measured one; measured number inside the range.
By their numbers in this assay, from the lowest: compounds 2, 1 and 3 (each within the scatter of the next).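

In this assay, cyclopentyl in place of isopentyl on the oxygen gives a 1.9-fold higher number from compound 2 to compound 3 (0.27 log units; within the scatter), so a five-membered ring of carbon in place of the open chain, with the same count of heavy atoms, does not separate the two compounds. The comparison with the nitrogen-linked ring gives a 1.3-fold higher number from compound 1 to compound 3 (0.10 log units; within the scatter), so cyclopentyloxy also cannot be told apart from pyrrolidin-1-yl, and this position has now held three different groups with no separable change in the number. Nothing available here accounts for this result.

The compounds shown leave open whether this insensitivity extends beyond these three groups. A methoxy, a longer chain or a carboxylic acid at this place might give quite a different number.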